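The source may report more compounds than this note shows. Statements on the series, on what has been measured and on what is new or still open speak of the compounds shown alone.

Of the compounds shown here, two sharing one core have been tested in an assay on isolated protein for inhibition of leukotriene B4 receptor 1 (Homo sapiens), tested at 10 uM; on this read-out higher numbers stand for more inhibition at the one concentration tested (going by the name of the read-out) and lower numbers for less inhibition. Compound 1 `C=CCc1cc(C(C)=O)c(O)cc1OCCCCCCCCC#N` gives 86% in this assay. Compound 2 `CCc1cc(C(C)=O)c(O)cc1OCCCC(C)(C)C#N` gives 85% in this assay; this is the smaller of the two numbers shown, but its gap to compound 1 lies within the usual scatter, so the two cannot be told apart. Compound 3 `CCc1cc(C(C)=O)c(O)cc1OCCCCCCC(C)(C)C#N` has not yet been measured in this assay. It differs from compound 2 in one place: 4-cyano-4-methylpentyl in place of 1-cyano-1-methylethyl on a saturated chain carbon, three bonds along the chain from an oxygen on an aromatic ring. Compound 3 is expected to show a step of no change at the digits printed from compound 2 to compound 3 (within the scatter) that stays within the scatter, because compound 1 carries a chain of similar length and gives 86% in this assay. Compound 3 is therefore estimated at 85% in this assay, with a likely range from 70% to 95%.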

Compound 3, a percentage reported as inhibition, at one concentration (the size of the read-out at that concentration, not a potency): 65%
Beside the measured number, compound 3's estimate is 20 percentage points above it, outside the stated range (below it).
By their numbers in this assay, from the lowest: compound 3; then compounds 2 and 1 (each within the scatter of the next).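

For the compounds shown here, this is the first step at this position that reaches beyond the scatter: in this assay, 4-cyano-4-methylpentyl in place of 1-cyano-1-methylethyl gives a number 20 percentage points lower from compound 2 to compound 3 (beyond the scatter). The two groups match in what is counted, each with a nitrile's triple bond, one hydrogen-bond acceptor, no ring and no net charge, and they differ in size, going from 5 to 8 heavy atoms, all of the added ones carbon, so the read-out does respond to a change at this place. Nothing measured here explains why the number falls.

On these data alone, with a single step, it remains open whether the number falls gradually or abruptly as the group grows, and a longer chain could continue the trend or break it. As far as these compounds go, it is also open how a carboxylic acid in place of the nitrile would behave on either chain.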